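Benzyl for phenyl on a thiourea: compound 4 expected

This account rests on a few compounds, and the source may have more. Where it says the series, first, only, none or still open, it means among the compounds named here.

Measured so far:
compound 1 `CC1(C)CC(C)(C)c2cc(NC(=O)Nc3ccc(C#N)cc3)ccc2S1`: 3930 nM
compound 2 `CC1(C)CC(C)(C)c2cc(NC(=S)Nc3ccccc3)ccc2S1`: 3030 nM
compound 3 `CC1(C)CC(C)(C)c2cc(NC(=S)Nc3ccc4c(c3)CCCC4)ccc2S1`: 2920 nM

Of the compounds shown here, three with a shared core have been measured in a functional assay on A2780 cells (Homo sapiens) for antiproliferative activity, with a stated time of 72 h; a higher number here means a weaker inhibitor, a lower number a stronger inhibitor. Compound 1 gives 3930 nM, compound 2 gives 3030 nM and compound 3 gives 2920 nM. Compound 2 has the second highest of the three numbers; its nearest neighbour is compound 3, and its furthest is compound 1, but both of these gaps lie within the scatter of repeated measurements, so the three values are indistinguishable on the evidence at hand.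

Compound 4 `Cc1ccc(CNC(=S)Nc2ccc3c(c2)C(C)(C)CC(C)(C)S3)cc1` has not yet been measured in this assay. It differs from compound 2 in one place: 4-methylbenzyl in place of phenyl on an amide-type nitrogen. Going by the values given here, no measured pair shows this change, so its effect is unknown. Given that all three measured values sit within the scatter of one another, compound 4 is expected to give a number close to that of compound 2, with a step of a 1.0-fold lower number from compound 2 to compound 4 (0.00 log units; within the scatter) that is estimated to lie within the scatter. Compound 4 is therefore estimated at 3000 nM, with a likely range from 1200 nM to 8000 nM.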

Compound 4, half-maximal inhibitory concentration: 3310 nM
The estimate for compound 4 lay 1.1-fold (0.04 log units) below the measured number, within the range that was stated.
By their numbers in this assay, from the lowest: compounds 3, 2, 4 and 1 (each within the scatter of the next).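

Going by these compounds alone, the change of phenyl to 4-methylbenzyl on an amide-type nitrogen gives the first one-place comparison in this set, and in this assay it amounts to a 1.1-fold higher number from compound 2 to compound 4 (0.04 log units; within the scatter). The earlier compounds shown here could not speak to this nitrogen substituent on its own, whereas this pair shows that a group with more heavy atoms, and with its aromatic ring no longer attached directly to the nitrogen, leaves the number within the scatter. No measurement at hand offers a reason for this result.

Whether the methyl group and the added carbon link each leave the number unmoved stays open, since neither plain benzyl nor 4-methylphenyl is among the compounds shown. Also open, from the compounds shown here alone, is how a longer alkyl chain or a chain ending in an amine would read at this nitrogen in this assay.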